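Swapping chloro for fluoro beside the sulfamate

The compounds below may be only part of what the source reports. "The series", "measured", "known", "first", "only" and "open" are said of these compounds alone.

Measured compounds:
- compound 3, `Cc1ccccc1N(C)C(=O)c1ccc(-c2ccc(OS(N)(=O)=O)c(Cl)c2)o1`: 25%
- compound 1, `Cc1ccccc1N(C)C(=O)c1ccc(-c2cccc(OS(N)(=O)=O)c2)o1`: "nd" (no result reported) (no result reported)
- compound 2, `Cc1ccccc1N(C)C(=O)c1ccc(-c2ccccc2OS(N)(=O)=O)o1`: "nd" (no result reported) (no result reported)

Three compounds share one core and were run in an assay on cytosol from placenta for inhibition of 17-beta-hydroxysteroid dehydrogenase type 1 (Homo sapiens), read by HPLC, with a stated time of 10 min, tested at 1 uM, in the presence of a further agent that is not named here; on this read-out lower numbers stand for less inhibition and higher numbers for more inhibition at the one concentration tested (going by the name of the read-out). Compound 1, with structure `Cc1ccccc1N(C)C(=O)c1ccc(-c2cccc(OS(N)(=O)=O)c2)o1`, and compound 2, with structure `Cc1ccccc1N(C)C(=O)c1ccc(-c2ccccc2OS(N)(=O)=O)o1`, have no result recorded in this assay. Within the data shown here, compound 3, with structure `Cc1ccccc1N(C)C(=O)c1ccc(-c2ccc(OS(N)(=O)=O)c(Cl)c2)o1`, gives 25% in this assay and therefore stands as the only compound with a number here; there is nothing to rank it against.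

The next compound is compound 4, `Cc1ccccc1N(C)C(=O)c1ccc(-c2ccc(OS(N)(=O)=O)c(F)c2)o1`. It differs from compound 3 in one place: fluoro in place of chloro on an aromatic carbon. One halogen is traded for another on the same aromatic carbon, so the change is small in size. Among the measured compounds shown here, with no step between measured compounds to draw on, the expected shift in this assay from compound 3 to compound 4 is small, not beyond the usual scatter, and if anything slightly downward.

For compound 4 the estimated inhibition in this assay is 20%, within the range 5% to 38%, which means an expected step of a number 5 percentage points lower from compound 3 to compound 4 (within the scatter).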

Compound 4, a percentage reported as inhibition, at one concentration (the size of the read-out at that concentration, not a potency): 18%
Beside the measured number, compound 4's estimate is 2 percentage points above it, within the range that was stated.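

In this assay, trading chloro for fluoro on this aromatic carbon, ortho to a sulfamoyloxy group, gives a number 7 percentage points lower from compound 3 to compound 4 (within the scatter). Among these compounds, this is the first comparison available at this position, and it shows that the two halogens cannot be told apart here. The choice between chloro and fluoro at this carbon therefore does not separate compound 3 from compound 4 on this read-out, and no measurement at hand explains the result.

The compounds shown leave open whether a different group on the same carbon, such as methoxy, an amine or a nitrile, would move the number beyond the usual scatter. Compound 1 and compound 2 have no result to compare, so they add nothing about where the sulfamoyloxy group is best placed.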